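This account rests on a few compounds, and the source may have more. Where it says the series, first, only, none or still open, it means among the compounds named here.

Working notes on the series. Compound 1 `CCOc1ccccc1NC(=O)CSc1c[nH]c2ccc(OC)cc12` and compound 3 `Cn1cc(SCC(=O)Nc2cc(Cl)ccc2Cl)c2ccccc21` are the two members that stop at a limit. In an ADME assay on HEK-293T cells (Homo sapiens) for cytotoxicity, read by CCK-8 assay, with a stated time of 48 h (on this read-out higher numbers stand for lower toxicity in this test and lower numbers for higher toxicity in this test), compound 1 reaches only a limit, > 100000 nM. In this assay compound 3 likewise gives a limit, > 100000 nM. Within the data shown here, compound 2 `O=C(CSc1c[nH]c2c(Cl)cccc12)Nc1ccc(Cl)c(Cl)c1` is the only member with a number: in this assay compound 2 gives 49100 nM. Among the measured compounds shown here, the other two values are a limit of this assay (the limit of > 100000 nM in this assay, at which 2 of the 3 values shown sit), so compound 2 is the one member that stands inside the measured range.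

Compound 4 `COc1cccc2c(SCC(=O)Nc3ccc(Cl)c(Cl)c3)c[nH]c12` differs from compound 2 by a single change: methoxy in place of chloro on an aromatic carbon. For the measured compounds named here, no measured step of this kind exists in the set. With compound 1 at its limit > 100000 nM as the only methoxy-bearing point, a step toward lower toxicity is expected, a 1.8-fold higher number from compound 2 to compound 4 (0.26 log units; within the scatter). Compound 4 is estimated at 90000 nM, between 40000 nM and 200000 nM.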

Compound 4, half-maximal cytotoxic concentration: > 100000 nM
Compound 4 was reported as a limit; the forecaster's own chance of this, stated with the estimate: 50%; at least 1.1-fold (0.04 log units) between middle value and limit.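

In this assay, among these compounds, methoxy in place of chloro on an aromatic carbon, ortho to a fused ring, gives the one step readable: an at least 2.0-fold higher number from compound 2 to compound 4 (0.30 log units; that floor lies within the scatter). This step is a floor and not a full size, and it leaves chloro as the only group at this position with a number: the limit of > 100000 nM in this assay, at which 3 of the 4 values shown sit.

From the compounds shown here alone, the true size of the step stays open. Also open, going by these compounds, is whether an amine or a hydroxyl at this position would give a number inside the measured range.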